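A few compounds are considered here, and "the series" means these few. Any claim that something is new, unique, unknown or untested is made for them only; others in the source may bear on it.

Measured:
compound 1 `CC(C)C(O)(C(=O)O)c1ccc(-c2ccc3ccccc3c2)[nH]c1=O` — 544 nM
compound 2 `CC(C)C(c1ncco1)c1ccc(-c2ccc3cccc(F)c3c2)[nH]c1=O` — 24 nM

In an assay on CHO cells for displacement of a labelled ligand from prostaglandin E2 receptor EP3 subtype (Homo sapiens), read by radioligand binding (a higher number here means a weaker inhibitor, a lower number a stronger inhibitor), compound 2 gives the lower of the two numbers shown; compound 1 gives the only other, and the gap between them lies beyond the scatter. Compound 3 `CC(C)C(c1cnc(N)s1)c1ccc(-c2ccc3cccc(F)c3c2)[nH]c1=O` differs from compound 2 in one place: 2-amino-1,3-thiazol-5-yl in place of 1,3-oxazol-2-yl on a saturated chain carbon bound to an aromatic carbon and a saturated chain carbon. Within the data shown here, no step between measured compounds isolates such an exchange, so its size in this assay is not anchored. A small step in either direction, or none beyond the scatter, is the expectation, with a modest loss held somewhat more likely. The estimated step is a 1.7-fold higher number from compound 2 to compound 3 (0.22 log units; within the scatter). Compound 3 is expected to give about 40 nM, within 8 nM to 200 nM.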

Compound 3, inhibition constant: 16 nM
Estimate against measurement, compound 3: 2.5-fold (0.40 log units) above; the range from low to high includes it.
By their numbers in this assay, from the lowest: compounds 3 and 2 (each within the scatter of the next); then compound 1.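

In this assay, replacing 1,3-oxazol-2-yl with 2-amino-1,3-thiazol-5-yl on the saturated chain carbon bound to an aromatic carbon and a saturated chain carbon gives a 1.5-fold lower number from compound 2 to compound 3 (0.18 log units; within the scatter) and leaves the reading within the scatter. This position therefore accepts either five-membered aromatic ring, even with the hydrogen-bond donor that enters with the second group. No supporting measurement bears on why the two groups read alike. Still open, from the compounds shown here alone, is whether this carbon tolerates a phenyl ring or a simple amine, since only these two rings have been compared here in a single-place exchange.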